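This account rests on a few compounds, and the source may have more. Where it says the series, first, only, none or still open, it means among the compounds named here.

Measured compounds:
- Compound 1 `O=C1C=C(NCc2ccccc2)C(=O)c2c1nc1n2[C@H]2OC[C@@H](O)[C@H]2OC1`: > 8000 nM, a limit of the assay
- Compound 2 `CCc1ccc(NC2=CC(=O)c3nc4n(c3C2=O)[C@H]2OC[C@@H](O)[C@H]2OC4)cc1`: 3080 nM
- Compound 3 `O=C1C=C(Nc2cccc(F)c2)C(=O)c2c1nc1n2[C@H]2OC[C@@H](O)[C@H]2OC1`: 7030 nM

The three compounds were tested in a functional assay on ECa-109 cells for inhibition, with ECa-109 cell line (Homo sapiens) as the target, read by sulforhodamine B assay; a lower number here means a stronger inhibitor, a higher number a weaker inhibitor. Of the two exact numbers, the higher belongs to compound 3, at 7030 nM. Compound 4 `CCOc1ccc(NC2=CC(=O)c3nc4n(c3C2=O)[C@H]2OC[C@@H](O)[C@H]2OC4)cc1` carries 4-ethoxyphenyl in place of 3-fluorophenyl on an amine nitrogen.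

The measured step closest to this change is a 2.3-fold higher number from compound 2 to compound 3 (0.36 log units; beyond the scatter), where 3-fluorophenyl replaces 4-ethylphenyl; it is modest but beyond the scatter. The incoming 4-ethoxyphenyl resembles the 4-ethylphenyl of compound 2, so that step is expected to run largely in reverse. The two steps from compound 1 add less, since each rests on a limit: an at least 2.5-fold lower number from compound 1 to compound 2 (0.41 log units; beyond the scatter) and an at least 1.1-fold lower number from compound 1 to compound 3 (0.05 log units; that floor lies within the scatter).

The expected change is a modest fall in the number, estimated as a 2.2-fold lower number from compound 3 to compound 4 (0.34 log units; beyond the scatter). Compound 4 is estimated at 3200 nM. The expected range for this estimate runs from 1400 nM to 7000 nM.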

Compound 4, half-maximal inhibitory concentration: 3210 nM
Estimate against measurement, compound 4: 1.0-fold (0.00 log units) below; measured number inside the range.
By their numbers in this assay, from the lowest: compounds 2 and 4 (each within the scatter of the next); then compound 3. At a limit, above all of these: compound 1.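

In this assay, ethoxy in place of ethyl on an aromatic carbon gives a 1.0-fold higher number from compound 2 to compound 4 (0.02 log units; within the scatter), so the two groups cannot be told apart at this amine nitrogen. The exchange of 3-fluorophenyl for 4-ethoxyphenyl gives a 2.2-fold lower number from compound 3 to compound 4 (0.34 log units; beyond the scatter), which makes compound 3 the only one of the three exact numbers set apart from the others. The step from benzyl, an at least 2.4-fold lower number from compound 1 to compound 4 (0.39 log units; beyond the scatter), is only a floor, and its starting value is a limit of the assay: the limit of > 8000 nM in this assay, at which 1 of the 4 values shown sits.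

The compounds shown leave open whether a 4-fluorophenyl would sit with compound 3 or with compound 2 and compound 4, which would separate the fluorine from its place on the ring. They also leave open whether a carboxylic acid, an amine or a longer alkoxy chain on the phenyl ring would be tolerated as ethyl and ethoxy are.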